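Ethylsulfanyl for methoxy on the side chain of compound 3

The source may hold more compounds than are shown below. What is called first, only, known or untested is meant among the compounds shown, and "the series" means these compounds.

Compound 3 `COCCCn1c(N2CCN(C)CC2)nc2ccccc21` stands at the highest number of the three measured compounds in a functional assay on ileum for inhibition of histamine H1 receptor (Cavia porcellus) (on this read-out lower numbers stand for stronger inhibition and higher numbers for weaker inhibition), giving 860 nM. Compound 1 `CCCOCCn1c(N2CCN(C)CC2)nc2ccccc21` gives 20 nM and compound 2 `CCCCCCCn1c(N2CCN(C)CC2)nc2ccccc21` gives 150 nM. The gap a 43-fold higher number from compound 1 to compound 3 (1.63 log units; beyond the scatter) is the largest in the set, while a 5.7-fold higher number from compound 2 to compound 3 (0.76 log units; beyond the scatter) is modest, as is a 7.5-fold higher number from compound 1 to compound 2 (0.88 log units; beyond the scatter).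

Compound 4 `CCSCCCn1c(N2CCN(C)CC2)nc2ccccc21` carries ethylsulfanyl in place of methoxy on a saturated chain carbon, three bonds along the chain from an aromatic nitrogen. The measured step that bears on it is a 5.7-fold higher number from compound 2 to compound 3 (0.76 log units; beyond the scatter), which concerns the same place on the chain and shows that a methoxy there goes with the weaker end of the series. The change from compound 3 to compound 4 removes that methoxy and puts in a chain group of three heavy atoms, so a step back in the lower direction is expected in this assay, of roughly the size seen in a 5.7-fold higher number from compound 2 to compound 3 (0.76 log units; beyond the scatter); the step of a 7.5-fold higher number from compound 1 to compound 2 (0.88 log units; beyond the scatter) concerns a different place and adds little.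

Compound 4 is expected to give 250 nM, with a range from 80 nM to 800 nM. The expected step is a 3.4-fold lower number from compound 3 to compound 4 (0.54 log units; beyond the scatter).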

Compound 4, half-maximal inhibitory concentration: 530 nM
Estimate against measurement, compound 4: 2.1-fold (0.33 log units) below; low and high end bracket the measured number.
By their numbers in this assay, from the lowest: compound 1; then compound 2; then compounds 4 and 3 (each within the scatter of the next).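

Ethylsulfanyl in place of methoxy, on a saturated chain carbon three bonds along the chain from an aromatic nitrogen, gives in this assay a 1.6-fold lower number from compound 3 to compound 4 (0.21 log units; within the scatter), so compound 3 and compound 4 cannot be told apart on this read-out. The butyl group remains clearly ahead of ethylsulfanyl at this place, with a 3.5-fold higher number from compound 2 to compound 4 (0.55 log units; beyond the scatter). The propoxy side chain also keeps its large lead, with a 27-fold higher number from compound 1 to compound 4 (1.42 log units; beyond the scatter), so the 3-(ethylsulfanyl)propyl chain does not approach the low number of compound 1.

Nothing at hand explains these steps. Going by these compounds, this change alters both the heteroatom and the group size, so their separate contributions stay open, as does the outcome with a hydroxyl or a dimethylamino group at this place.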